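A few compounds are considered here, and "the series" means these few. Any claim that something is new, unique, unknown or untested is made for them only; others in the source may bear on it.

Compound 1 `CNC(=O)C1=C[C@@H]2[C@@H](C(C)C)CC[C@@](O)(CO)[C@H]2C(=O)OC1` is the starting point here, and in a functional assay on HCT-116 cells (Homo sapiens) for inhibition, with a stated time of 72 h (on this read-out higher numbers stand for weaker inhibition and lower numbers for stronger inhibition), compound 1 gives > 32000 nM. On these data alone, that reading is a limit of the assay and not a number, so the true position of compound 1 is unknown. Two relatives do give real numbers: compound 2 `CC(C)[C@H]1CC[C@@]2(CO2)[C@H]2C(=O)OCC(C(=O)OCc3ccc(-c4ccccc4)o3)=C[C@H]12` reads 220 nM, and compound 3 `CC(C)[C@H]1CC[C@@](O)(CCl)[C@H]2C(=O)OCC(C(=O)OCc3ccc(-c4ccccc4)o3)=C[C@H]12` reads 610 nM. Both differ from compound 1 in more than one place, so neither shows what a single change does.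

Compound 4 `CC(C)[C@H]1CC[C@@](O)(CO)[C@H]2C(=O)OCC(C(=O)O)=C[C@H]12` keeps the core of compound 1 and changes one group. It has hydroxy in place of methylamino on a carbonyl carbon, which turns methylcarbamoyl to carboxy (hydroxy in place of methylamino on a carbonyl carbon).

Among the compounds with values here, no measured pair of compounds shows this change, so its size in this assay cannot be read from the data, and the expectation is for no shift beyond the usual scatter. That expectation leans on compound 1, whose > 32000 nM is a limit. The estimated step, a step that the limit leaves unreadable from compound 1 to compound 4, is therefore expected to be small and without a clear direction. For compound 4 the expected value is 40000 nM, with an estimated range from 20000 nM to 100000 nM.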

Compound 4, half-maximal inhibitory concentration: > 32000 nM
Compound 4: only a limit was reported (the forecaster's own chance of this, stated with the estimate: 85%); the middle value is on the limit's open side.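

In this assay compound 4 gives > 32000 nM as a limit of the assay and not a number. Compound 1 also has only a limit, so no step can be read from compound 1 to compound 4: the limit of > 32000 nM in this assay, at which 2 of the 4 values shown sit.

The compounds shown leave open how strongly compound 1 and compound 4 really inhibit, and what hydroxy in place of methylamino does by itself.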